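A few compounds are considered here, and "the series" means these few. Any claim that something is new, unique, unknown or untested is made for them only; others in the source may bear on it.

Compound 1 `O=C(Nc1ccc([N+](=O)[O-])cc1)Nn1c(-c2ccccc2)nc2ccccc2c1=O`: in a functional assay on the whole organism (strain albino) with Mus musculus as the target, at a dose of 100 mg/kg by the intraperitoneal route (on this read-out higher numbers stand for more inhibition at the one dose given (going by the name of the read-out) and lower numbers for less inhibition), compound 1 gives 42%.
Compound 2 `Cc1cccc(NC(=O)Nn2c(-c3ccccc3)nc3ccccc3c2=O)c1`: in this assay compound 2 gives 59%.

Compound 2 stands highest of the two numbers in this assay; its nearest neighbour is compound 1, and the step of a number 17 percentage points higher from compound 1 to compound 2 (beyond the scatter) lies beyond the usual scatter. Compound 3 `CCc1nc2ccccc2c(=O)n1NC(=O)Nc1cccc(C)c1` has not yet been measured. It differs from compound 2 in one place: ethyl in place of phenyl on an aromatic carbon.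

Among the measured compounds shown here, the single measured step, a number 17 percentage points higher from compound 1 to compound 2 (beyond the scatter), exchanged a group on an amide-type nitrogen, a different part of the shared core from the aromatic carbon changed here, so no measured step bears directly on this change. With nothing closer to rest on, compound 3 is expected to change by only a number 9 percentage points lower from compound 2 to compound 3 (within the scatter), a step within the scatter, but the uncertainty is large. The estimate for compound 3 in this assay is 50%, with a range from 25% to 75%.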

Compound 3, a percentage reported as inhibition, in the whole organism at one dose (the size of the read-out at that dose, not a potency): 53%
Compound 3: the middle estimate sits 3 percentage points below what was measured, within the range that was stated.
By their numbers in this assay, from the lowest: compound 1; then compounds 3 and 2 (each within the scatter of the next).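

In this assay, this position between two ring nitrogen atoms now has a measured step of its own: ethyl in place of phenyl gives a number 6 percentage points lower from compound 2 to compound 3 (within the scatter). At this place, then, a six-membered aromatic ring of 6 heavy atoms gave way to an ethyl group of 2 heavy atoms with no ring, and the read-out stayed within the usual scatter, so in this pair the ring was not needed to keep the inhibition seen at this dose. No measurement at hand explains why the two groups read alike.

The compounds shown leave open whether a longer chain, an amine or a carboxylic acid at this position would also read alike. They also leave open whether the same exchange would hold with 4-nitrophenyl in place of 3-methylphenyl on the amide-type nitrogen.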